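A few compounds are considered here, and "the series" means these few. Any claim that something is new, unique, unknown or untested is made for them only; others in the source may bear on it.

Working notes on the series. Within the data shown here, in a functional assay on KBVIN cells (Homo sapiens) for antiproliferative activity, read by sulforhodamine B assay, with a stated time of 3 days (a higher number here means a weaker inhibitor of growth, a lower number a stronger inhibitor of growth), compound 3 `O=C(c1cccc(Nc2ncc(F)c(Nc3ccc(F)cc3)n2)c1)N1CCCCC1` gives 13800 nM, the only true number so far. Compound 1 `O=C(Nc1nccs1)c1cccc(Nc2ncc(F)c(Nc3ccc(F)cc3)n2)c1` reads > 10000 nM, which is a limit and not a number. Compound 2 `O=C(Nc1ccc(C(F)(F)F)cc1)c1cccc(Nc2ncc(F)c(Nc3ccc(F)cc3)n2)c1` reads > 10000 nM, which is also a limit. The picture so far is therefore set by the limit of > 10000 nM in this assay, at which 2 of the 3 values shown sit.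

Compound 4 `COc1cc(NC(=O)c2cccc(Nc3ncc(F)c(Nc4ccc(F)cc4)n3)c2)cc(OC)c1` carries (3,5-dimethoxyphenyl)amino in place of piperidin-1-yl on a carbonyl carbon.

Two measured steps make a change at that same carbonyl carbon: a step that the limit leaves unreadable from compound 1 to compound 3, and a step that the limit leaves unreadable from compound 2 to compound 3. Neither has a readable size, so neither supplies a number to carry over, and the reverse direction of travel cannot be read from them either. The closest match to compound 4 is compound 2, which also has an arylamino group on the carbonyl carbon and which stands at > 10000 nM. Among the measured compounds shown here, no measured compound in this set shows strong growth inhibition, so no gain is expected from the new group. The expected change is a 1.0-fold higher number from compound 3 to compound 4 (0.01 log units; within the scatter), which means no shift beyond the scatter in either direction in this assay. For compound 4 the estimate is 14000 nM, with an expected range of 7000 nM to 30000 nM, and a report as a limit alone is also quite likely.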

Compound 4, concentration for 50% growth inhibition: 12700 nM
For compound 4 the middle estimate is 1.1-fold (0.04 log units) above the measured one; the range from low to high includes it.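

In this assay the carbonyl carbon now has its first readable step: a 1.1-fold lower number from compound 3 to compound 4 (0.04 log units; within the scatter). Piperidin-1-yl and (3,5-dimethoxyphenyl)amino differ in ring type, in heavy atoms and in hydrogen-bond donors and acceptors, yet this exchange does not separate them, and an arylamino group on this carbon now carries a true number rather than a limit. The steps from compound 1 and from compound 2 to compound 4 cannot be read, and a single limit still sets much of the picture: the limit of > 10000 nM in this assay, at which 2 of the 4 values shown sit.

From the compounds shown here alone, it remains open whether any other group on this carbonyl carbon, such as a morpholine, a piperazine or a carboxylic acid on the aryl ring, would move the number beyond the scatter in this assay. It also remains open whether a change elsewhere on the shared core, rather than at this carbon, would give a clearly lower number, since the compounds shown vary in this one place only.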